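Notes on an inverted ether linker in the series

The source may hold more compounds than are shown below. What is called first, only, known or untested is meant among the compounds shown, and "the series" means these compounds.

Compound 2 `O=C(O)/C=C/c1ccc(COc2ccccc2)cc1OCCc1ccc2ccccc2c1` was measured in an in vitro functional assay on CHO cells for antagonist activity at prostaglandin E2 receptor EP3 subtype (Mus musculus) (a higher number here means a weaker inhibitor, a lower number a stronger inhibitor), where compound 2 gives 140 nM. Going by the values given here, compound 1 `O=C(O)/C=C/c1ccc(Cn2cccn2)cc1OCCc1ccc2ccccc2c1` is the only other measured member of the set; in this assay compound 1 gives 73 nM. Compound 2 carries the higher of the two numbers, but the gap from compound 1 is a 1.9-fold higher number from compound 1 to compound 2 (0.28 log units; within the scatter), inside the usual scatter, so no order between the two can be read from it.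

Compound 3 `O=C(O)/C=C/c1ccc(OCc2ccccc2)cc1OCCc1ccc2ccccc2c1` differs from compound 2 by benzyloxy in place of phenoxymethyl on an aromatic carbon. The two compounds contain the same atoms joined differently, so the change is a rearrangement of the linker rather than an addition or removal of any group.

Among the compounds with values here, the single measured step, a 1.9-fold higher number from compound 1 to compound 2 (0.28 log units; within the scatter), concerns a different change on the chain carbon and lies within the scatter; no measured step in the set bears on reversing an ether linker, so no direction can be drawn from precedent. The step from compound 2 to compound 3 in this assay is therefore expected to be a 1.1-fold higher number from compound 2 to compound 3 (0.03 log units; within the scatter), nothing beyond the scatter. Compound 3 is estimated at 150 nM, with a range of 50 nM to 450 nM.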

Compound 3, half-maximal inhibitory concentration: 1500 nM
For compound 3 the middle estimate is 10-fold (1.00 log units) below the measured one; the measured number lies above the stated range.
By their numbers in this assay, from the lowest: compounds 1 and 2 (each within the scatter of the next); then compound 3.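

In this assay, the aromatic carbon para to the 2-carboxyethenyl group proves sensitive to how the linker atoms are joined: with the same atoms present, benzyloxy in place of phenoxymethyl gives an 11-fold higher number from compound 2 to compound 3 (1.03 log units; beyond the scatter) and thus a large step, which the earlier change at the chain carbon did not show. Benzyloxy in place of (1H-pyrazol-1-yl)methyl gives a 21-fold higher number from compound 1 to compound 3 (1.31 log units; beyond the scatter) as well, so among these three compounds the two groups joined to the aromatic carbon through a saturated chain carbon stay within the scatter of each other, while the group joined through oxygen stands clearly apart, with no compound here going against this. Nothing available explains why reversing the ether linker has an effect of this size.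

The compounds shown leave open whether the large step follows the oxygen on the aromatic carbon or the overall arrangement of the linker, a question that a 2-phenylethyl or a benzylamino group at this place would help to separate. They also leave open whether a pyrazole carried on a longer chain, or a fluorine on the terminal phenyl ring, would keep the numbers near those of the first two compounds.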